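Replacing the Dimethylimidazolyl Group of Compound 3 with Tetrazolyl

A few compounds are considered here, and "the series" means these few. Any claim that something is new, unique, unknown or untested is made for them only; others in the source may bear on it.

Compound 1, `CCC(C)n1ncn(-c2ccc(N3CCN(c4ccc(OC[C@@H]5CO[C@@](CC6CCCC6)(c6ccc(Cl)cc6Cl)O5)cc4)CC3)cc2)c1=O`, gives 512 nM in a functional assay on HUVEC cells (Homo sapiens), read by scintillation counting and thymidine incorporation, with a stated time of 24 h; on this read-out lower numbers stand for stronger inhibition and higher numbers for weaker inhibition.
Compound 2, `CCc1nccn1C[C@@]1(c2ccc(Cl)cc2Cl)OC[C@@H](COc2ccc(N3CCN(c4ccc(-n5cnn(C(C)CC)c5=O)cc4)CC3)cc2)O1`, gives 224 nM in this assay.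
Compound 3, `CCC(C)n1ncn(-c2ccc(N3CCN(c4ccc(OC[C@@H]5CO[C@@](Cn6c(C)cnc6C)(c6ccc(Cl)cc6Cl)O5)cc4)CC3)cc2)c1=O`, gives 765 nM in this assay.

Compound 3 stands at the highest number of the three; its gap to compound 1 is within the scatter, while its gap to compound 2 is beyond it. Compound 4, `CCC(C)n1ncn(-c2ccc(N3CCN(c4ccc(OC[C@@H]5CO[C@@](Cn6nnnc6C)(c6ccc(Cl)cc6Cl)O5)cc4)CC3)cc2)c1=O`, differs from compound 3 in one place: 5-methyl-1H-tetrazol-1-yl in place of 2,5-dimethyl-1H-imidazol-1-yl on a saturated chain carbon bound to a saturated ring carbon. All measured steps change the group at that same place: a 2.3-fold lower number from compound 1 to compound 2 (0.36 log units; beyond the scatter), a 1.5-fold higher number from compound 1 to compound 3 (0.17 log units; within the scatter), a 3.4-fold higher number from compound 2 to compound 3 (0.53 log units; beyond the scatter). These steps are modest at most, and none involves a 5-methyl-1H-tetrazol-1-yl group, so they bear only loosely on this change. Compound 4 is therefore expected to show no step beyond the scatter, a 1.1-fold lower number from compound 3 to compound 4 (0.04 log units; within the scatter). The estimate for compound 4 is 700 nM, with a range from 250 nM to 2000 nM.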

Compound 4, half-maximal inhibitory concentration: 101 nM
Compound 4: middle estimate off by 6.9-fold (0.84 log units), on the high side; the measured number lies below the stated range.
By their numbers in this assay, from the lowest: compound 4; then compound 2; then compounds 1 and 3 (each within the scatter of the next).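

The step of a 7.6-fold lower number from compound 3 to compound 4 (0.88 log units; beyond the scatter) is the largest seen at this place on the saturated chain carbon, so swapping one five-membered aromatic ring for another can matter more here than the earlier changes suggested. The 5-methyl-1H-tetrazol-1-yl group also outperforms the other groups, with a 2.2-fold lower number from compound 2 to compound 4 (0.35 log units; beyond the scatter) and a 5.1-fold lower number from compound 1 to compound 4 (0.70 log units; beyond the scatter) as further steps, leaving compound 4 with the lowest number of the four. No measurement here explains this difference.

Still open, from the compounds shown here alone, is whether the methyl on the tetrazole is needed, and whether a 1,2,4-triazol-1-yl or an ethyl-bearing tetrazole would give a similar number.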